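The source may hold more compounds than are shown below. What is called first, only, known or untested is meant among the compounds shown, and "the series" means these compounds.

Compound 1 `O=C(Nc1cccc(-c2oc3cc(-c4ccc(F)cc4)ccc3c(=O)c2O)c1)c1cc(F)cc(F)c1` gives 2490 nM in a functional assay on MCF7 cells (Homo sapiens) for antiproliferative activity, read by CCK-8 assay, with a stated time of 72 h; on this read-out lower numbers stand for stronger inhibition and higher numbers for weaker inhibition. Compound 2 `O=C(Nc1cccc(-c2oc3cc(-c4ccc(F)cc4)ccc3c(=O)c2O)c1)c1ccc([N+](=O)[O-])cc1` gives 3970 nM.

Within the data shown here, compound 2 carries the highest of the two numbers, yet the step of a 1.6-fold higher number from compound 1 to compound 2 (0.20 log units; within the scatter) is the only measured step, and it lies within the scatter. Compound 3 `CCCc1ccc(C(=O)Nc2cccc(-c3oc4cc(-c5ccc(F)cc5)ccc4c(=O)c3O)c2)cc1` differs from compound 2 by propyl in place of nitro on an aromatic carbon. Among the measured compounds shown here, no measured step touches the group that enters here, so the account rests on the step from compound 1 to compound 2 alone, which showed no change beyond the scatter. Compound 3 is therefore expected to show a 1.3-fold lower number from compound 2 to compound 3 (0.12 log units; within the scatter), an estimated 3000 nM with a range from 1000 nM to 9000 nM.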

Compound 3, half-maximal inhibitory concentration: 36800 nM
The estimate for compound 3 lay 12-fold (1.09 log units) below the measured number; measured number above the stated range.
By their numbers in this assay, from the lowest: compounds 1 and 2 (each within the scatter of the next); then compound 3.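

Propyl in place of nitro, para to a large group, brings a 9.3-fold higher number from compound 2 to compound 3 (0.97 log units; beyond the scatter) in this assay and so shows that this position responds to the group it carries, which the earlier step did not show. The 4-propylphenyl group also separates from 3,5-difluorophenyl with a 15-fold higher number from compound 1 to compound 3 (1.17 log units; beyond the scatter) on the same read-out, whereas 4-nitrophenyl and 3,5-difluorophenyl stayed within the scatter of each other. Nothing measured here accounts for this weaker inhibition.

On these data alone, it remains open whether an amine, a methyl group or a longer chain at this position would read like nitro or like propyl.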